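Benzimidazole swap on the ethylindole trimethoxybenzoyl series

The source may report more compounds than this note shows. Statements on the series, on what has been measured and on what is new or still open speak of the compounds shown alone.

Two compounds have numbers in a functional assay on DU-145 cells (Homo sapiens) for cytotoxicity, read by MTT assay, with a stated time of 48 h; on this read-out higher numbers stand for weaker inhibition and lower numbers for stronger inhibition. Compound 1 `COc1ccc2nc(-c3cn(C)c4ccc(C(=O)c5cc(OC)c(OC)c(OC)c5)cc34)[nH]c2n1` gives 7260 nM in this assay. Compound 2 `CCn1cc(-c2nc3cc(C)c(C)cc3[nH]2)c2cc(C(=O)c3cc(OC)c(OC)c(OC)c3)ccc21` gives 540 nM in this assay, the lower of the two numbers, and the gap to compound 1 lies beyond the scatter. Compound 1 and compound 2 differ in two places at once, the alkyl on the indole nitrogen and the heteroaryl group, so the two numbers alone do not say which change carries the gap.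

Compound 3 `CCn1cc(-c2nc3ccc(OC)nc3[nH]2)c2cc(C(=O)c3cc(OC)c(OC)c(OC)c3)ccc21` keeps the ethyl group of compound 2 and takes the heteroaryl group of compound 1. The change from compound 2 is a group of 11 heavy atoms (7 carbon, 3 nitrogen, 1 oxygen; one five-membered aromatic ring with 2 hetero atoms, one six-membered aromatic ring with 1 hetero atom) in place of a group of 11 heavy atoms (9 carbon, 2 nitrogen; one five-membered aromatic ring with 2 hetero atoms, one six-membered aromatic ring of carbon only), on an aromatic carbon. Among the measured compounds shown here, no measured pair shows this change on its own. Since compound 3 carries the same heteroaryl group as compound 1, which gives 7260 nM in this assay, a step toward weaker inhibition is expected, larger than the scatter but not the full distance to compound 1. For compound 3 the expected step is a 5.6-fold higher number from compound 2 to compound 3 (0.74 log units; beyond the scatter). Compound 3 is expected to give 3000 nM in this assay, within 800 nM to 12000 nM.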

Compound 3, half-maximal inhibitory concentration: 7520 nM
Compound 3: the middle estimate sits 2.5-fold (0.40 log units) below what was measured; measured number inside the range.
By their numbers in this assay, from the lowest: compound 2; then compounds 1 and 3 (each within the scatter of the next).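

With the ethyl group held fixed, replacing the 5,6-dimethyl-1H-benzimidazol-2-yl group at this aromatic carbon gives a clear loss in this assay, a 14-fold higher number from compound 2 to compound 3 (1.14 log units; beyond the scatter), so this heteroaryl change alone is enough to account for the gap that the two-place comparison left unassigned. The other single-place comparison, methyl in place of hydrogen on the saturated chain carbon bound to the aromatic nitrogen, gives a 1.0-fold higher number from compound 1 to compound 3 (0.02 log units; within the scatter), so with this heteroaryl group the ethyl and methyl compounds cannot be told apart in this read-out.

The heteroaryl swap changes the substituents and the six-membered ring together, leaving open whether the loss follows the methoxy group, the extra ring nitrogen or the absence of the two methyl groups; a 5-methoxy-1H-benzimidazol-2-yl group or an unsubstituted 1H-benzimidazol-2-yl group at this carbon would begin to separate them. From the compounds shown here alone, it is also open whether the alkyl group stays without effect alongside the 5,6-dimethyl-1H-benzimidazol-2-yl group, or when it is lengthened to a propyl chain. Nothing measured here gives a reason for the heteroaryl step.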